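This account rests on a few compounds, and the source may have more. Where it says the series, first, only, none or still open, it means among the compounds named here.

Compound 1 `COc1cccc(Nc2nc3cc(Cl)ccc3c(=O)[nH]2)c1`: > 25000 nM
Compound 2 `O=c1[nH]c(Nc2cccc(O)c2)nc2cc(Cl)ccc12`: > 25000 nM

In an ADME assay on Vero cells (Chlorocebus sabaeus) for cytotoxicity, read by WST assay (a higher number here means that more compound is tolerated, a lower number that less compound is tolerated), compound 1 gives > 25000 nM, which is a limit of the assay rather than a number. Compound 2 gives > 25000 nM, likewise a limit. The step from these two values, a step that the two limits leave unreadable from compound 1 to compound 2, therefore cannot be sized, because the limit of > 25000 nM in this assay, at which 2 of the 2 values shown sit, is all that is seen. Compound 3 `O=c1[nH]c(Nc2cc(O)cc(O)c2)nc2cc(Cl)ccc12` differs from compound 2 by hydroxy in place of hydrogen on an aromatic carbon. Among the compounds with values here, the one measured step that bears on this change is unreadable, so no shift beyond the scatter is expected. Compound 3 is expected at 30000 nM (15000 nM to 60000 nM). This estimate corresponds to an expected step that the limit leaves unreadable from compound 2 to compound 3.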

Compound 3, half-maximal cytotoxic concentration: > 25000 nM
Compound 3 ended at the assay's limit (the forecaster's own chance of this, stated with the estimate: 85%); the middle value does not contradict the limit.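

In this assay, within the data shown here, compound 2 and compound 3 both give only a limit, not a number, so no step between them can be read: the limit of > 25000 nM in this assay, at which 3 of the 3 values shown sit. The compounds shown leave open how much of each compound is truly tolerated and whether the added hydroxy changes that.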